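The source may report more compounds than this note shows. Statements on the series, on what has been measured and on what is new or still open speak of the compounds shown alone.

Measured compounds:
compound 1, `CN(C(=O)NC(=O)c1ccc(Cl)cc1Cl)c1nc(C(F)(F)F)c(C(=O)N/N=C/c2cccc(C(F)(F)F)c2)s1`, gives 10.7 ug/mL in a functional assay on MCF7 cells (Homo sapiens) for inhibition, read by MTT assay, with a stated time of 72 h; a higher number here means a weaker inhibitor, a lower number a stronger inhibitor.
compound 2, `CN(C(=O)NC(=O)c1ccc(Cl)cc1Cl)c1nc(C(F)(F)F)c(C(=O)N/N=C/c2cc(C(F)(F)F)cc(C(F)(F)F)c2)s1`, gives > 100 ug/mL in this assay, which is a limit of the assay and not a number.
compound 3, `CN(C(=O)NC(=O)c1c(F)cccc1F)c1nc(C(F)(F)F)c(C(=O)N/N=C/c2ccc(C(F)(F)F)cc2)s1`, gives 35.3 ug/mL in this assay.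

Compound 2 therefore stands at the limit of this assay; only a bound and no number is known for it. It differs from compound 1 in one place, and the step of an at least 9.3-fold higher number from compound 1 to compound 2 (0.97 log units; beyond the scatter) runs into that bound, as the limit of > 100 ug/mL in this assay, at which 1 of the 3 values shown sits, records.

Compound 4, `CN(C(=O)NC(=O)c1c(F)cccc1F)c1nc(C(F)(F)F)c(C(=O)N/N=C/c2cc(C(F)(F)F)cc(C(F)(F)F)c2)s1`, differs from compound 2 by 2,6-difluorophenyl in place of 2,4-dichlorophenyl on a carbonyl carbon. For the measured compounds named here, no measured step covers this change alone. Going by the values given here, compound 1 and compound 3 carry the same two aryl groups but also differ elsewhere, so their values show only that compound 1 gives 10.7 ug/mL while compound 3 gives 35.3 ug/mL in this assay, a gap that is beyond the scatter but not attributable to the aryl change by itself.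

With compound 2 already at the limit, the expected step that the limit leaves unreadable from compound 2 to compound 4 is essentially none that can be resolved. Compound 4 is expected to give 150 ug/mL, within a range from 40 ug/mL to 500 ug/mL, and most likely to be reported again only as a limit.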

Compound 4, half-maximal inhibitory concentration: 6.85 ug/mL
Estimate against measurement, compound 4: 22-fold (1.34 log units) above; the measured number lies below the stated range.
By their numbers in this assay, from the lowest: compounds 4 and 1 (each within the scatter of the next); then compound 3. At a limit, above all of these: compound 2.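

For the compounds shown here, the change of 2,4-dichlorophenyl to 2,6-difluorophenyl on the carbonyl carbon is the first change at this position that can be read by itself, and in this assay it gives an at least 14-fold lower number from compound 2 to compound 4 (1.16 log units; beyond the scatter). So the aryl group at this position decides whether a compound carrying two trifluoromethyl groups on its other aryl ring gives a measurable value or stays at a limit, which the earlier step alone could not show. The size of this step remains a bound and not a number: the limit of > 100 ug/mL in this assay, at which 1 of the 4 values shown sits.

Going by these compounds alone, with only this one pair, it stays open whether the same change would act alike in a compound carrying a single trifluoromethyl group. From the compounds shown here alone, it is also open whether the gain follows the exchange of chlorine for fluorine or the different substitution pattern, and how a methoxy group or an amine on this phenyl ring would read.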